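Title: Methylating the thioamide nitrogen of compound 2

This account rests on a few compounds, and the source may have more. Where it says the series, first, only, none or still open, it means among the compounds named here.

Compound 1: `N=C(S)CCCCCCn1nc(-c2ccccc2)ccc1=O`, > 100 mg/kg
Compound 2: `N=C(S)CCCCCn1nc(-c2ccccc2)ccc1=O`, 23.3 mg/kg

For the measured compounds named here, in a functional assay on the whole organism (stomach) with Rattus norvegicus as the target (a higher number here means that more compound is needed for the effect, a lower number that less compound is needed), compound 2 gives 23.3 mg/kg, the only true number among the values shown. For compound 1 the assay reports only a limit, > 100 mg/kg, and this compound therefore sits at the limit of > 100 mg/kg in this assay, at which 1 of the 2 values shown sits. Going by the values given here, the one measured step, an at least 4.2-fold lower number from compound 1 to compound 2 (0.63 log units; beyond the scatter), concerns the length of the chain and not the group at its end.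

Compound 3, `C/N=C(/S)CCCCCn1nc(-c2ccccc2)ccc1=O`, differs from compound 2 by a group of 4 heavy atoms (2 carbon, 1 nitrogen, 1 sulfur; no ring) in place of a group of 3 heavy atoms (1 carbon, 1 nitrogen, 1 sulfur; no ring), on a saturated chain carbon, five bonds along the chain from an aromatic nitrogen. Among the compounds with values here, no measured step changes this terminal group, so the chain-length step gives no direct guide to this change. Compound 3 is therefore expected to stay near compound 2, with a 1.3-fold higher number from compound 2 to compound 3 (0.11 log units; within the scatter), not beyond the scatter. The estimate for compound 3 in this assay is 30 mg/kg, within a range from 10 mg/kg to 100 mg/kg.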

Compound 3, dose for half-maximal effect: 25.2 mg/kg
The estimate for compound 3 lay 1.2-fold (0.08 log units) above the measured number; low and high end bracket the measured number.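

In this assay, methylating the thioamide nitrogen gives a 1.1-fold higher number from compound 2 to compound 3 (0.03 log units; within the scatter), so this first change to the terminal group, where 2 hydrogen-bond donors give way to 1 hydrogen-bond donor, leaves the dose needed indistinguishable from that of the parent. The earlier step had shown only that the length of the chain matters, whereas this one shows that the end of the chain accepts a methyl group without a change beyond the scatter, and the gap to the longer-chain compound remains, at an at least 3.9-fold lower number from compound 1 to compound 3 (0.59 log units; beyond the scatter). For the compounds shown here, that gap rests on a limit, which is the only kind of value compound 1 has here: the limit of > 100 mg/kg in this assay, at which 1 of the 3 values shown sits.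

From the compounds shown here alone, whether an ethyl or a benzyl group on the same nitrogen would hold this level stays open. So does the effect of an amide or a carboxylic acid at the chain end, or of a shorter chain.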